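The source may report more compounds than this note shows. Statements on the series, on what has been measured and on what is new or still open speak of the compounds shown alone.

The series shares one core, carried by compound 1 `C/C=C/C(=O)N(Cc1cccc(O)c1)c1cc(OC)c(OC)c(OC)c1`, compound 2 `CCC/C=C/C(=O)N(Cc1ccc(OC)c(O)c1)c1cc(OC)c(OC)c(OC)c1` and compound 3 `CCC(=O)N(Cc1ccc(OC)c(O)c1)c1cc(OC)c(OC)c(OC)c1`, which differ in the group on the carbonyl carbon and in the substitution of the benzyl ring. In a functional assay on KYSE-450 cells (Homo sapiens) for inhibition, read by MTT assay, with a stated time of 48 h (a lower number here means a stronger inhibitor, a higher number a weaker inhibitor), compound 1 gives 14700 nM. Compound 2 gives 57 nM, and compound 3 gives 98 nM. Going by the values given here, compound 3 thus stands second highest of the three numbers: the step of a 1.7-fold higher number from compound 2 to compound 3 (0.24 log units; within the scatter) lies within the scatter, while compound 1 sits far higher, though it differs from compound 3 in two places, so no single step joins them.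

Compound 4 `COc1ccc(CN(C(=O)C2CC2)c2cc(OC)c(OC)c(OC)c2)cc1O` is not yet measured. Against compound 3 it shows (cyclopropyl in place of ethyl on a carbonyl carbon). Among the compounds with values here, the only measured step at the same position is a 1.7-fold higher number from compound 2 to compound 3 (0.24 log units; within the scatter), which exchanged a longer unsaturated chain for a short saturated one without moving the number beyond the scatter. Nothing in the data links a three-membered ring on the carbonyl carbon to a change in this assay, so the expected step of a 1.1-fold lower number from compound 3 to compound 4 (0.04 log units; within the scatter) is small, with no direction beyond the scatter. Compound 4 is therefore expected to give 90 nM in this assay, with a range from 40 nM to 250 nM.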

Compound 4, half-maximal inhibitory concentration: 80 nM
Estimate against measurement, compound 4: 1.1-fold (0.05 log units) above; measured number inside the range.
By their numbers in this assay, from the lowest: compounds 2, 4 and 3 (each within the scatter of the next); then compound 1.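

Cyclopropyl in place of ethyl on a carbonyl carbon puts a ring at this position for the first time, and in this assay the step of a 1.2-fold lower number from compound 3 to compound 4 (0.09 log units; within the scatter) stays within the scatter. The wider exchange of pent-1-en-1-yl for cyclopropyl at the same carbon, a 1.4-fold higher number from compound 2 to compound 4 (0.15 log units; within the scatter), also stays within the scatter, so with the benzyl ring of compound 2, compound 3 and compound 4 unchanged, this assay does not tell an unsaturated chain, a short saturated chain and a three-membered ring apart. No independent measurement bears on why these three groups give such similar numbers.

From the compounds shown here alone, it remains open whether a cyclohexyl or phenyl group, or a group carrying an amine or a carboxylic acid, on the same carbonyl carbon would also stay within the scatter of these three compounds. The part played by the substitution of the benzyl ring is open as well: compound 1 differs from compound 3 in two places, and the data assign its number to neither place alone.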